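Acylguanidine series: swapping the cyclohexyl end group

The compounds below may be only part of what the source reports. "The series", "measured", "known", "first", "only" and "open" are said of these compounds alone.

Within the data shown here, compound 1, `COc1ccc(Br)cc1CCc1c(F)cccc1C(=O)/N=C(\N)NCCC1CCCCC1`, gives the lowest of the two numbers so far in an assay for binding affinity to Melanocortin receptor 4 (Homo sapiens) (on this read-out higher numbers stand for weaker inhibition and lower numbers for stronger inhibition), at 2600 nM. Compound 2, `CCN(CC)CCCC(C)/N=C(\NC(=O)c1cccc(F)c1CCc1cc(Br)ccc1OC)Nc1ccccc1`, gives 4100 nM in this assay, which lies within the scatter of compound 1, so no order between the two can be read. Compound 3, `COc1ccc(Br)cc1CCc1c(F)cccc1C(=O)/N=C(\N)NCCCN1CCN(C)CC1`, differs from compound 1 by one change: (4-methylpiperazin-1-yl)methyl in place of cyclohexyl on a saturated chain carbon, two bonds along the chain from an amine nitrogen. Among the measured compounds shown here, no measured pair shows this change, so any expectation rests on compound 1 alone. Compound 3 is expected to give 1500 nM in this assay, somewhere between 400 nM and 6000 nM. The step of a 1.7-fold lower number from compound 1 to compound 3 (0.24 log units; within the scatter) is expected to stay small, toward a lower number but not clearly beyond the scatter.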

Compound 3, inhibition constant: 64 nM
Compound 3: the middle estimate sits 23-fold (1.37 log units) above what was measured; measured number outside the range, below it.
By their numbers in this assay, from the lowest: compound 3; then compounds 1 and 2 (each within the scatter of the next).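

This position is far from indifferent in this assay: with (4-methylpiperazin-1-yl)methyl in place of cyclohexyl on the saturated chain carbon, the result is a 41-fold lower number from compound 1 to compound 3 (1.61 log units; beyond the scatter), a large step beyond the scatter. The change brings two nitrogens into the six-membered ring, which in cyclohexyl holds carbon only, and so replaces a carbon-only end group with one holding hetero atoms. Nothing available explains the size of this step.

The compounds shown leave open whether both ring nitrogens and the methyl group are needed. A piperidine, a morpholine or an open dimethylamino end group on the same chain would address this, and a shorter or longer chain would test the spacing.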